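Amino Substitution Raises Growth-Inhibition Values in Lung Cells

The source may report more compounds than this note shows. Statements on the series, on what has been measured and on what is new or still open speak of the compounds shown alone.

Measured compounds: compound 1 `ClCc1ccc(Cn2cnc3c(Cl)ncnc32)cc1` at 660 nM; compound 2 `Nc1nc(Cl)c2ncn(Cc3ccc(CCl)cc3)c2n1` at 12000 nM; compound 3 `ClCc1ccccc1Cn1cnc2c(Cl)ncnc21` at 2040 nM.

In a functional assay on NCI-H23 cells (Homo sapiens) for cytotoxicity, read by sulforhodamine B assay, with a stated time of 48 h (a lower number here means a stronger inhibitor of growth, a higher number a weaker inhibitor of growth), compound 1 gives 660 nM, compound 2 gives 12000 nM, and compound 3 gives 2040 nM. Compound 1 and compound 2 differ by amino in place of hydrogen on an aromatic carbon, and this produced an 18-fold higher number from compound 1 to compound 2 (1.26 log units; beyond the scatter). Compound 3 is built from the same atoms as compound 1, joined differently; the difference between the two cores is not broken down here. Compound 4 `Nc1nc(Cl)c2ncn(Cc3ccccc3CCl)c2n1` has not yet been measured. It differs from compound 3 by amino in place of hydrogen on an aromatic carbon, the same change at the same place as in the measured pair. Because an 18-fold higher number from compound 1 to compound 2 (1.26 log units; beyond the scatter) is large, a step of comparable size is expected here, a 12-fold higher number from compound 3 to compound 4 (1.09 log units; beyond the scatter). Compound 4 is therefore estimated at 25000 nM, with a range from 8000 nM to 80000 nM.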

Compound 4, concentration for 50% growth inhibition: 3020 nM
The estimate for compound 4 lay 8.3-fold (0.92 log units) above the measured number, and the stated range ends above it.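

In this assay, amino in place of hydrogen on an aromatic carbon gave a 1.5-fold higher number from compound 3 to compound 4 (0.17 log units; within the scatter), and the change did not keep its size from one core to the other: the same change on two cores in this assay, an 18-fold higher number (1.26 log units; beyond the scatter) from compound 1 to compound 2 and a 1.5-fold higher number (0.17 log units; within the scatter) from compound 3 to compound 4, 12-fold (1.09 log units) apart, beyond the scatter of two such steps

The large step seen on the core of compound 1 therefore cannot be assumed to carry over to another core in this series. The two pairs do not show which difference between the cores goes with the gap, and they give no rule for any further core.

The compounds shown leave open whether a methylamino group or a hydroxyl group in place of the amino would show a similar gap between these two cores. They also leave open how the change would behave on a third core.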